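The source may hold more compounds than are shown below. What is called first, only, known or untested is meant among the compounds shown, and "the series" means these compounds.

Measured so far:
- compound 1 `COc1ccc(/C(=N/OC(C)=O)c2cccc3ccccc23)c(OC)c1OC`: 17200 nM
- compound 2 `COc1ccc(C(c2ccc(OCCO)cc2)c2cccc3ccccc23)c(OC)c1OC`: > 20000 nM

In a functional assay on A549 cells (Homo sapiens) for inhibition, read by sulforhodamine B assay, with a stated time of 48 h (a lower number here means a stronger inhibitor, a higher number a weaker inhibitor), compound 1 gives 17200 nM, the only numeric result in the set. For compound 2 this assay returns only a limit, > 20000 nM, so it is a boundary of the assay and not a number; this is the limit of > 20000 nM in this assay, at which 1 of the 2 values shown sits. Going by the values given here, compound 1 therefore stands as the sole quantified point, with no step between measured compounds to draw on.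

Compound 3 `COc1ccc(/C(=N/OCC(=O)O)c2cccc3ccccc23)c(OC)c1OC` is the next candidate. The difference from compound 1 is carboxymethyl in place of acetyl on an oxygen.

Among the compounds with values here, with no measured step available, the expectation rests on compound 1 alone and on the change itself. The step from compound 1 to compound 3 is expected to be small and, if anything, towards a weaker inhibitor, close to or just beyond the scatter: a 1.5-fold higher number from compound 1 to compound 3 (0.16 log units; within the scatter). For compound 3 the estimate in this assay is 25000 nM, with a range from 8000 nM to 80000 nM, and a real chance that only a limit is reported.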

Compound 3, half-maximal inhibitory concentration: 17200 nM
Compound 3: middle estimate off by 1.5-fold (0.16 log units), on the high side; the range from low to high includes it.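

On the oxygen bonded to the double-bonded nitrogen, the series now has its first measured step in this assay, which reads no change at the digits printed from compound 1 to compound 3 (within the scatter). Acetyl and carboxymethyl, which differ by one hydrogen-bond donor in the counts for the two groups, are therefore not told apart at this oxygen in this assay, and the exchange brings no gain in inhibition. Compound 2 still adds no second step, as its result is a limit and not a number: the limit of > 20000 nM in this assay, at which 1 of the 3 values shown sits.

From the compounds shown here alone, whether a methyl ester of the carboxymethyl group, an aminoethyl group or a longer chain on this oxygen would separate from these two groups remains open. Also open, going by these compounds, is whether any change to the shared core would give a lower number in this assay.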